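Rearranging a Saturated Ring Group Near the Assay Limit

This account rests on a few compounds, and the source may have more. Where it says the series, first, only, none or still open, it means among the compounds named here.

In an ADME assay on MDBK cells (Bos taurus) for cytotoxicity, read by MTT assay (a higher number here means that more compound is tolerated, a lower number that less compound is tolerated), compound 3 `CC1CCCC(OCCCCCCN2C[C@H](O)[C@@H](O)[C@H](O)[C@H]2CO)C1C` gives > 500000 nM, which is a limit of the assay and not a number. Compound 1 `CCC1CCC(OCCCCCCN2C[C@H](O)[C@@H](O)[C@H](O)[C@H]2CO)CC1` gives > 500000 nM, again a limit. Compound 2 `OC[C@@H]1[C@@H](O)[C@H](O)[C@@H](O)CN1CCCCCCOc1cc(Cl)ccc1Cl` gives a true number, 320000 nM, the only one so far. The picture is therefore dominated by the limit of > 500000 nM in this assay, at which 2 of the 3 values shown sit.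

Compound 4 `CCC1CCCCC1OCCCCCCN1C[C@H](O)[C@@H](O)[C@H](O)[C@H]1CO` has the same atoms as compound 3, joined differently: a group of 8 heavy atoms (8 carbon; one six-membered non-aromatic ring of carbon only) in place of a group of 8 heavy atoms (8 carbon; one six-membered non-aromatic ring of carbon only), on an oxygen on a saturated carbon. The change sits on an oxygen on a saturated carbon, and the rest of the molecule stays as it was.

Going by the values given here, three measured steps bear on this. Among the compounds with values here, compound 1 and compound 3 carry two different groups of this same kind, so the closest precedent is a step that the two limits leave unreadable from compound 1 to compound 3, and on that evidence no step beyond the scatter is expected in this assay for the new swap. The other two steps run through compound 2, whose group has an aromatic ring: an at least 1.5-fold lower number from compound 1 to compound 2 (0.19 log units; that floor lies within the scatter) and an at least 1.5-fold higher number from compound 2 to compound 3 (0.19 log units; that floor lies within the scatter). They are less close to the present change.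

The expected change is a number no higher from compound 3 to compound 4 (the limit leaves the size open). For compound 4 the estimated value is 500000 nM, with an expected range from 250000 nM to 1000000 nM, and it may well be reported only as a limit.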

Compound 4, half-maximal cytotoxic concentration: 450000 nM
Estimate against measurement, compound 4: 1.1-fold (0.05 log units) above; the range from low to high includes it.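

Compound 4 gives 450000 nM in this assay, so a group with a six-membered non-aromatic ring of carbon only now has a true number on an oxygen on a saturated carbon. Compound 1 and compound 3 offered only limits. The new floors, an at least 1.1-fold lower number from compound 3 to compound 4 (0.04 log units; that floor lies within the scatter) and an at least 1.1-fold lower number from compound 1 to compound 4 (0.04 log units; that floor lies within the scatter), lie within the scatter, so neither shows that rearranging these same carbon atoms has a real effect on tolerance in this series. Set against the aromatic group of compound 2, the saturated group of compound 4 gives a 1.4-fold higher number from compound 2 to compound 4 (0.15 log units; within the scatter), and this measured step shows that these two compounds cannot be told apart in this assay.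

From the compounds shown here alone, the other steps among the saturated groups cannot be read, and the true size of any difference among compound 1, compound 3 and compound 4 stays open because the data are still held at an assay limit: the limit of > 500000 nM in this assay, at which 2 of the 4 values shown sit. Also open, going by these compounds, is how a ring group carrying an amine or a carboxylic acid would behave at this place in this assay.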